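The source may hold more compounds than are shown below. What is called first, only, known or untested is meant among the compounds shown, and "the series" means these compounds.

In a physicochemical assay for solubility, using the shake flask method, measured as kinetic solubility, with a stated time of 20 h, at pH 2 (on this read-out higher numbers stand for higher solubility and lower numbers for lower solubility), the measured compounds are:
- compound 1 `COc1cccnc1Nc1cc2[nH]c(-c3cccc(C(F)(F)F)c3)nc2cn1` gives 116000 nM
- compound 2 `COc1ccnc(Nc2cc3[nH]c(-c4cccc(C(F)(F)F)c4)nc3cn2)c1` gives < 5000 nM as a limit

Going by the values given here, compound 1 thus holds the only true number so far. Compound 3 `FC(F)(F)c1cccc(-c2nc3cnc(Nc4ncccn4)cc3[nH]2)c1` carries pyrimidin-2-yl in place of 3-methoxypyridin-2-yl on a nitrogen on an aromatic ring and keeps the rest of compound 1. Among the compounds with values here, one measured step bears on this place, with 4-methoxypyridin-2-yl entering: an at least 23-fold lower number from compound 1 to compound 2 (1.36 log units; beyond the scatter) is large, but it is a single step that ends in a limit of < 5000 nM in this assay, at which 1 of the 2 values shown sits, and so gives thin support. A smaller step in the same direction is expected, namely a 7.7-fold lower number from compound 1 to compound 3 (0.89 log units; beyond the scatter) in this assay as the working figure. Compound 3 is estimated at 15000 nM with an expected range of 3000 nM to 70000 nM for now.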

Compound 3, solubility: 155000 nM
Compound 3: the middle estimate sits 10-fold (1.01 log units) below what was measured; measured number outside the range, above it.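

In this assay, leaving 3-methoxypyridin-2-yl does not by itself go with a lower number: pyrimidin-2-yl reads level with it (a 1.3-fold higher number from compound 1 to compound 3 (0.13 log units; within the scatter)). The low reading at this position is so far confined to 4-methoxypyridin-2-yl, since pyrimidin-2-yl also separates from that group (an at least 31-fold higher number from compound 2 to compound 3 (1.49 log units; beyond the scatter)). Compound 2 remains a limit, not a number: the limit of < 5000 nM in this assay, at which 1 of the 3 values shown sits.

Still open, on these data alone, is how far the reading at this position tolerates other groups, such as an amine or a carboxylic acid in place of the methoxy group. With one true number on each side of the level step, no trend across the position can yet be stated.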